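The compounds below may be only part of what the source reports. "The series", "measured", "known", "first", "only" and "open" are said of these compounds alone.

Among the compounds with values here, in a functional assay on P815 cells (Mus musculus) for inhibition, read by microscopy and colony formation, with a stated time of 7 days, tested at 5 uM (a higher number here means a stronger effect of the compound at the concentration tested, a lower number a weaker effect), compound 1 `COc1cc([C@H]2C=CC[C@@H]3C(=O)OC[C@@H]32)cc(OC)c1OC` gives 89%, the higher of the two numbers measured so far. Compound 2 `COc1cc([C@H]2C=CC[C@@H]3COC(=O)[C@H]32)cc(OC)c1OC` gives 42% in this assay, a gap that lies beyond the usual scatter. Compound 3 `COc1cc([C@H]2C=CC[C@@H]3C(=O)OC[C@H]32)cc(OC)c1OC` has not yet been measured. Relative to compound 1 the change is small on paper: the two compounds have the same atoms and bonds and differ only in configuration as drawn: 1 of 3 stereo elements differ; a stereocentre at a saturated ring carbon is drawn R in compound 1 and S in compound 3. Within the data shown here, no step between two measured compounds shows what such a change does in this assay, so the direction is open; a loss of some size seems somewhat more likely than a gain, with wide uncertainty. Compound 3 is expected to give about 55%, between 20% and 90%. The step estimated is a number 34 percentage points lower from compound 1 to compound 3 (beyond the scatter).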

Compound 3, a percentage reported as activity, at one concentration (the size of the read-out at that concentration, not a potency): 95%
Compound 3: the middle estimate sits 40 percentage points below what was measured; measured number outside the range, above it.
By their numbers in this assay, from the lowest: compound 2; then compounds 1 and 3 (each within the scatter of the next).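

In this assay, the saturated ring carbon stereocentre accepts either drawn configuration, R or S, with a number 6 percentage points higher from compound 1 to compound 3 (within the scatter). Within the data shown here, this is the first readable step, and it gives no sign that this centre governs the read-out at the single concentration tested. The comparison isolates configuration alone: the fact that compounds 1 and 3 differ only in the configuration as drawn

On these data alone, whether compound 1 and compound 3 would separate at other concentrations stays open. So does the effect of an amine or a carboxylic acid on the shared core.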